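Azetidinyl in place of fluoro on the pyridyl arm

The source may hold more compounds than are shown below. What is called first, only, known or untested is meant among the compounds shown, and "the series" means these compounds.

Compound 2 `O=C(O)Cc1sc(C(c2ccc(F)cc2)c2ccc(F)cc2)nc1-c1ccnc(F)c1` is measured in an in vitro functional assay on HEK285-7 cells for antagonist activity at prostaglandin D2 receptor 2 (Homo sapiens), read by BRET and beta-arrestin recruitment (on this read-out lower numbers stand for smaller maximal responses and higher numbers for larger maximal responses), where compound 2 gives 80%. Compound 1 `O=C(O)Cc1sc(C(c2ccccc2)c2ccc(Cl)cc2)nc1-c1ccc(F)cc1` gives 80% in this assay, and the two values are level within the scatter. Compound 3 `O=C(O)Cc1sc(C(c2ccc(F)cc2)c2ccc(F)cc2)nc1-c1ccnc(N2CCC2)c1` is not yet measured; it differs from compound 2 by azetidin-1-yl in place of fluoro on an aromatic carbon. Within the data shown here, no measured pair shows this change, so the expectation rests on compound 2 alone. The step from compound 2 to compound 3 is expected to be a number 2 percentage points lower from compound 2 to compound 3 (within the scatter), none beyond the scatter. Compound 3 is therefore estimated at 78%, with a range from 60% to 95%.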

Compound 3, largest response reached (reported as efficacy), in percent of the reference or control that the assay uses: 80%
Compound 3: the middle estimate sits 2 percentage points below what was measured, and the stated range covers the measured number.
By their numbers in this assay, from the lowest: compounds 1, 2 and 3 (each within the scatter of the next).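

Azetidin-1-yl in place of fluoro, next to the ring nitrogen, gives no change at the digits printed from compound 2 to compound 3 (within the scatter) in this assay, the first single-place step read at this position. For this one pair, the position holds a four-membered non-aromatic ring where compound 2 carries a lone fluorine, with the maximal response unmoved. Nothing shown gives a reason for this result.

As far as these compounds go, whether morpholin-4-yl, a larger ring, or a primary amine at the same carbon would read alike stays open. So does whether azetidin-1-yl would behave this way elsewhere on the shared core.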